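The source may report more compounds than this note shows. Statements on the series, on what has been measured and on what is new or still open speak of the compounds shown alone.

In a functional assay for inhibition, read by fluorescence and spectrophotometry, with a stated time of 30 h (on this read-out lower numbers stand for stronger inhibition and higher numbers for weaker inhibition), compound 3 (`COc1ccc(-c2cc(=O)c3ccc(OCCCCCN4CCC(C)CC4)cc3o2)cc1`) gives 55100 nM, within the scatter of compound 1 (`COc1ccc(-c2cc(=O)c3ccc(OCCCN4CCC(C)CC4)cc3o2)cc1`) at 42600 nM and of compound 2 (`COc1ccc(-c2cc(=O)c3ccc(OCCCCN4CCC(CCO)CC4)cc3o2)cc1`) at 38400 nM. Compound 4 (`COc1ccc(-c2cc(=O)c3ccc(OCCCCCN4CCC(CCO)CC4)cc3o2)cc1`) differs from compound 3 by hydroxymethyl in place of hydrogen on a saturated chain carbon bound to a saturated ring carbon, on a saturated chain carbon bound to a saturated ring carbon, which also reads methyl to 2-hydroxyethyl. Among the measured compounds shown here, no measured step isolates this change at constant chain length. The nearest steps combine it with a chain change: a 1.1-fold lower number from compound 1 to compound 2 (0.05 log units; within the scatter) and a 1.4-fold higher number from compound 2 to compound 3 (0.16 log units; within the scatter). The chain change alone gives a 1.3-fold higher number from compound 1 to compound 3 (0.11 log units; within the scatter). All three lie within the scatter. The expected change in this assay is a 1.1-fold lower number from compound 3 to compound 4 (0.06 log units; within the scatter), no step beyond the scatter. For compound 4 the estimated value is 48000 nM, with an expected range of 26000 nM to 85000 nM.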

Compound 4, half-maximal inhibitory concentration: 49400 nM
Compound 4: the middle estimate sits 1.0-fold (0.01 log units) below what was measured, within the range that was stated.
By their numbers in this assay, from the lowest: compounds 2, 1, 4 and 3 (each within the scatter of the next).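

In this assay the move from methyl to 2-hydroxyethyl at constant chain length is now read directly, on a saturated chain carbon bound to a saturated ring carbon: there is a 1.1-fold lower number from compound 3 to compound 4 (0.05 log units; within the scatter) and the step lies within the scatter. The two steps that also change the chain (a 1.3-fold higher number from compound 2 to compound 4 (0.11 log units; within the scatter) and a 1.2-fold higher number from compound 1 to compound 4 (0.06 log units; within the scatter)) lie within the scatter as well, so neither hydroxymethyl nor chain length separates these four compounds. No evidence on the cause of this is at hand.

Going by these compounds, whether a carboxylic acid or a primary amine at the end of this substituent, or a much shorter chain, would give a step beyond the scatter remains open.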